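The source may hold more compounds than are shown below. What is called first, only, known or untested is meant among the compounds shown, and "the series" means these compounds.

Measured compounds in a functional assay on HeLa cells (Homo sapiens) for cytotoxicity, read by MTT assay, with a stated time of 24 h; a lower number here means a stronger inhibitor, a higher number a weaker inhibitor:

Compound 1 `COc1cc(/C=C2\CN(C)C/C(=C\c3ccc(Br)cc3)C2=O)cc(OC)c1` gives 5900 nM.
Compound 2 `COc1cc(/C=C2\CN(C)C/C(=C\c3ccc(Cl)cc3Cl)C2=O)cc(OC)c1` gives 7760 nM.
Compound 3 `CN1C/C(=C\c2ccc(Br)cc2)C(=O)/C(=C/c2ccc(C#N)cc2)C1` gives 5900 nM.

Compounds 1 and 2 share one core, and the change between them is 2,4-dichlorophenyl in place of 4-bromophenyl on a double-bonded chain carbon bound to a double-bonded ring carbon. The step it made was a 1.3-fold higher number from compound 1 to compound 2 (0.12 log units; within the scatter). Compound 3 carries a different core; the difference between the two cores is not broken down here. In this assay compound 3 stands level with compound 1 at the digits shown, and the two together hold the lowest numbers of the three, while compound 2 sits a little higher, though all three values lie within the scatter of one another.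

Compound 4 `CN1C/C(=C\c2ccc(C#N)cc2)C(=O)/C(=C/c2ccc(Cl)cc2Cl)C1` has not yet been measured in this assay. It arises from compound 3 by 2,4-dichlorophenyl in place of 4-bromophenyl on a double-bonded chain carbon bound to a double-bonded ring carbon, the same change that leads from compound 1 to compound 2; the change occurs in these two pairs and in no other among the compounds shown. Since the earlier step was a 1.3-fold higher number from compound 1 to compound 2 (0.12 log units; within the scatter), a similar step is expected here: a 1.3-fold higher number from compound 3 to compound 4 (0.12 log units; within the scatter) is the estimate, resting on compound 3 with 5900 nM as the starting point. Compound 4 is therefore expected to give about 7700 nM, with a likely range from 4500 nM to 13000 nM.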

Compound 4, half-maximal inhibitory concentration: 7760 nM
For compound 4 the middle estimate is 1.0-fold (0.00 log units) below the measured one, within the range that was stated.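

In this assay, 2,4-dichlorophenyl in place of 4-bromophenyl gave a 1.3-fold higher number from compound 3 to compound 4 (0.12 log units; within the scatter), and the change carried from one core to the other with a step of matching size: the same change on two cores in this assay, a 1.3-fold higher number (0.12 log units; within the scatter) from compound 1 to compound 2 and a 1.3-fold higher number (0.12 log units; within the scatter) from compound 3 to compound 4, 1.0-fold (0.00 log units) apart, within the scatter of two such steps. Going by these compounds alone, both steps lie within the scatter, so the agreement shows only that this change left the number about where it stood on both cores, not that it reliably raises the number. The comparison rests on just two pairs and a single change, so it says nothing about other cores or about whether a change with a step beyond the scatter would carry across in the same way.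

From the compounds shown here alone, it remains open whether an amine, a carboxylic acid or a longer chain in place of 2,4-dichlorophenyl would move the number beyond the scatter on either core. Going by these compounds, every value shown comes from this assay, so how the same change behaves in any other assay also remains open.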